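A Methyl Branch on the Acid Side Chain

A few compounds are considered here, and "the series" means these few. Any claim that something is new, unique, unknown or untested is made for them only; others in the source may bear on it.

Of the compounds shown here, two have so far been measured in an assay on cell membranes (Cavia porcellus) for binding affinity to leukotriene B4 receptor 1 (Homo sapiens); a higher number here means a weaker inhibitor, a lower number a stronger inhibitor. Compound 1 `CCCc1cc(OCCCOc2ccc(C(C)=O)c(OC)c2CCC)cc2c1OC(C(=O)O)CC2` gives 15.4 nM in this assay, while compound 2 `CCCc1c(OCCCOc2cc(O)c(C(C)=O)cc2CC)cccc1OCC(=O)O` gives 4.96 nM, the lower of the two numbers and thus the stronger inhibitor of the pair.

Compound 3 `CCCc1c(OCCCOc2cc(O)c(C(C)=O)cc2CC)cccc1OC(C)C(=O)O` has not yet been measured. It differs from compound 2 by methyl in place of hydrogen on a saturated chain carbon bound to a carbonyl carbon and an oxygen on an aromatic ring, so that a carboxymethoxy group becomes a 1-carboxyethoxy group.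

Among the compounds with values here, no step between measured compounds shows what such an added methyl does here, so no direction can be read from these data. The chemist therefore expects the step from compound 2 to compound 3 in this assay to be small, not clearly beyond the usual scatter, and puts it at a 1.3-fold higher number from compound 2 to compound 3 (0.12 log units; within the scatter). On that basis compound 3 is estimated at 6.5 nM in this assay, with a range from 2 nM to 20 nM.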

Compound 3, inhibition constant: 18.5 nM
Estimate against measurement, compound 3: 2.8-fold (0.45 log units) below; low and high end bracket the measured number.
By their numbers in this assay, from the lowest: compound 2; then compounds 1 and 3 (each within the scatter of the next).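

Methyl in place of hydrogen on the saturated chain carbon bound to a carbonyl carbon and an oxygen on an aromatic ring comes at a cost in this assay: it gives a 3.7-fold higher number from compound 2 to compound 3 (0.57 log units; beyond the scatter) and turns compound 2, the stronger of the earlier pair, into a weaker inhibitor. Within the data shown here, compounds 1 and 2 differ in more than one place, so only this step isolates a change at this carbon, and it shows that carboxymethoxy is preferred here over 1-carboxyethoxy. Nothing measured here accounts for the step.

The compounds shown leave open whether an ethyl group or a second methyl on this same carbon would raise the number further. They also leave open whether the same methyl would have a comparable effect on the core of compound 1.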